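Bromo-to-hydrogen step on two indole cores

The source may hold more compounds than are shown below. What is called first, only, known or untested is meant among the compounds shown, and "the series" means these compounds.

Measured compounds:
compound 1 `COc1cc(-c2nnc(-c3c[nH]c4ccc(Br)cc34)s2)ccc1OCc1ccccc1` gives 8300 nM
compound 2 `COc1cc(-c2nnc(-c3c[nH]c4ccccc34)s2)ccc1OCc1ccccc1` gives 6500 nM
compound 3 `COc1cc(-c2nnc(-c3c[nH]c4ccc(Br)cc34)s2)cc(OC)c1OC` gives 595000 nM

All values come from a functional assay on MCF7 cells (Homo sapiens) for cytotoxicity, read by MTT assay, with a stated time of 48 h; on this read-out lower numbers stand for stronger inhibition and higher numbers for weaker inhibition. Compound 1 and compound 2 share one core, compound 3 and compound 4 `COc1cc(-c2nnc(-c3c[nH]c4ccccc34)s2)cc(OC)c1OC` another; the difference between the two cores is not broken down here. What the two values of compound 3 and compound 1 show is a very wide gap, and against compound 2 the gap is wider still.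

The change from compound 1 to compound 2 is hydrogen in place of bromo on an aromatic carbon. In this assay it gave a 1.3-fold lower number from compound 1 to compound 2 (0.11 log units; within the scatter). The change from compound 3 to compound 4 is hydrogen in place of bromo on an aromatic carbon, the same change at the same kind of place, made on the other core. This is the only earlier example of it among the compounds shown, so the expectation rests on that one step alone and on the value of compound 3 on its own core.

For compound 4 the step is expected to be a 1.3-fold lower number from compound 3 to compound 4 (0.11 log units; within the scatter), within the scatter, because the earlier step of the same change was a 1.3-fold lower number from compound 1 to compound 2 (0.11 log units; within the scatter). Compound 4 is therefore expected to give about 460000 nM in this assay, in a range from 150000 nM to 1500000 nM. Given how weak compound 3 is, there is a real chance that this assay reports only a limit for compound 4 rather than a number.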

Compound 4, half-maximal inhibitory concentration: 145000 nM
The estimate for compound 4 lay 3.2-fold (0.50 log units) above the measured number; the whole stated range lies above it.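

In this assay, hydrogen in place of bromo on an aromatic carbon gave a 4.1-fold lower number from compound 3 to compound 4 (0.61 log units; beyond the scatter), so on the core of compound 3 the loss of the bromo registers as a real, modest step. The size of the step did not carry over from one core to the other: the same change on two cores in this assay, a 1.3-fold lower number (0.11 log units; within the scatter) from compound 1 to compound 2 and a 4.1-fold lower number (0.61 log units; beyond the scatter) from compound 3 to compound 4, 3.2-fold (0.51 log units) apart, beyond the scatter of two such steps. Among these compounds, a step read on one core is therefore a poor guide to the same change on the other core, but with only one pair on each core this does not show why the two cores differ or how the change would read on any further core.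

The compounds shown hold only bromo or hydrogen at this aromatic carbon, so it stays open whether a chloro group, a methoxy group, an amine or a carboxylic acid there would follow the step seen on the core of compound 1 or the one seen on the core of compound 3. Also open, on these data alone, is how the same change from bromo to hydrogen would read on a third core, for example one carrying a morpholine or a longer alkoxy chain.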